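The source may hold more compounds than are shown below. What is called first, only, known or untested is meant among the compounds shown, and "the series" means these compounds.

Compound 3, `COc1ccc(/C(=C(/CCNC(=O)NCc2ccccc2)c2ccccc2)c2ccccc2)cc1`, stands in a functional assay on MCF7 cells (Homo sapiens) for cytotoxicity, read by MTT assay, with a stated time of 72 h (a lower number here means a stronger inhibitor, a higher number a weaker inhibitor), at > 50000 nM, which is a limit of the assay and not a number. Compound 1, `COc1ccc(/C(=C(/CCCl)c2ccccc2)c2ccccc2)cc1`, likewise sits at > 50000 nM, again a limit. Compound 2, `COc1ccc(/C(=C(/CCNC(=O)Oc2ccccc2)c2ccccc2)c2ccccc2)cc1`, is recorded as "not active" (no number reported). Two of the three values therefore rest at the limit of > 50000 nM in this assay, at which 2 of the 3 values shown sit. Among the measured compounds shown here, the only measured step, a step that the two limits leave unreadable from compound 1 to compound 3, cannot be sized from these two limits. Compound 4, `COc1ccc(/C(=C(/CCNC(=O)C(=O)NC2CCCCC2)c2ccccc2)c2ccccc2)cc1`, differs from compound 3 by cyclohexylcarbamoyl in place of benzylamino on a carbonyl carbon. For the measured compounds named here, no measured step tells how such a change shifts this assay, so nothing beyond the scatter can be argued in either direction. Compound 4 is accordingly expected near 60000 nM, within 15000 nM to 200000 nM, a step that the limit leaves unreadable from compound 3 to compound 4 that is an estimate only.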

Compound 4, half-maximal inhibitory concentration: 12100 nM
Compound 4: middle estimate off by 5.0-fold (0.70 log units), on the high side; the measured number lies below the stated range.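

In this assay, among the compounds shown here, replacing benzylamino with cyclohexylcarbamoyl on the carbonyl carbon gives an at least 4.1-fold lower number from compound 3 to compound 4 (0.61 log units; beyond the scatter), the first change at this chain end to bring a reading inside the assay's range. Against the chloro group, the ((cyclohexylcarbamoyl)carbonyl)amino group gives an at least 4.1-fold lower number from compound 1 to compound 4 (0.61 log units; beyond the scatter). Both sizes are floors only, because compound 1 and compound 3 each rest on a limit of the assay: the limit of > 50000 nM in this assay, at which 2 of the 4 values shown sit.

The change swaps the ring and adds a carbonyl at once, and the compounds shown do not separate the two. Also open, as far as these compounds go, is whether an amine or a carboxylic acid in place of the cyclohexyl ring would hold this activity.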